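This account rests on a few compounds, and the source may have more. Where it says the series, first, only, none or still open, it means among the compounds named here.

Series notes. The three measured compounds share one core and differ in the aryl on the aromatic nitrogen and in whether the central anilide ring carries a fluorine. Compound 1 `O=C(Nc1ccc(Oc2ccnc3[nH]ccc23)cc1)c1nn(-c2ccc(Cl)c(F)c2)ccc1=O` lacks that fluorine and in a functional assay on MCF7 cells (Homo sapiens) for cytotoxicity, read by MTT assay, with a stated time of 72 h (a higher number here means a weaker inhibitor, a lower number a stronger inhibitor), compound 1 gives 3110 nM. Compound 2 `O=C(Nc1ccc(Oc2ccnc3[nH]ccc23)c(F)c1)c1nn(-c2ccccc2)ccc1=O` carries the fluorine with a plain phenyl, and in this assay compound 2 gives 34900 nM. Compound 3 `O=C(Nc1ccc(Oc2ccnc3[nH]ccc23)c(F)c1)c1nn(-c2ccc(Br)cc2F)ccc1=O` keeps that fluorine and in this assay compound 3 gives 23500 nM, the second highest of the three numbers; its nearest neighbour is compound 2 and its furthest compound 1.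

Within the data shown here, the one step that bears on the aryl position is a 1.5-fold lower number from compound 2 to compound 3 (0.17 log units; within the scatter). Compound 4 `O=C(Nc1ccc(Oc2ccnc3[nH]ccc23)c(F)c1)c1nn(-c2ccc(Cl)c(F)c2)ccc1=O` differs from compound 3 by 4-chloro-3-fluorophenyl in place of 4-bromo-2-fluorophenyl on an aromatic nitrogen. Among the measured compounds shown here, the same 4-chloro-3-fluorophenyl sits on compound 1, but compound 1 also lacks the central fluorine, so its lower number cannot be assigned to the aryl alone; no step separates compound 1 from compound 3 or compound 4. With one within-scatter aryl step and one confounded comparison, the step of a 2.4-fold lower number from compound 3 to compound 4 (0.37 log units; beyond the scatter) is expected to lean toward a lower number without certainty. Compound 4 is estimated at 10000 nM, with a range from 3000 nM to 35000 nM in this assay.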

Compound 4, half-maximal inhibitory concentration: 11600 nM
Compound 4: the middle estimate sits 1.2-fold (0.06 log units) below what was measured; measured number inside the range.
By their numbers in this assay, from the lowest: compound 1; then compound 4; then compounds 3 and 2 (each within the scatter of the next).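

In this assay, the aryl on the aromatic nitrogen now gives steps beyond the scatter, though modest ones: 4-chloro-3-fluorophenyl in place of phenyl gives a 3.0-fold lower number from compound 2 to compound 4 (0.48 log units; beyond the scatter) and in place of 4-bromo-2-fluorophenyl gives a 2.0-fold lower number from compound 3 to compound 4 (0.31 log units; beyond the scatter), so this position responds to the aryl, whereas 4-bromo-2-fluorophenyl in place of phenyl stayed within the scatter. Among these compounds, compound 1 and compound 4 also form the first pair that differs only in the fluoro on an aromatic carbon of the anilide ring, and with 4-chloro-3-fluorophenyl held constant, fluoro in place of hydrogen gives a 3.7-fold higher number from compound 1 to compound 4 (0.57 log units; beyond the scatter), which removes the confound that earlier kept the lower number of compound 1 from being read. No measurement at hand accounts for either change.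

Since 4-chloro-3-fluorophenyl and 4-bromo-2-fluorophenyl differ in both the halogens and their placement, the compounds shown do not separate chlorine for bromine from the shift of the fluorine, and the cost of the anilide fluoro is read with only one aryl. Going by these compounds, how an amine or a carboxylic acid on the aryl would read in this assay remains open.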